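A few compounds are considered here, and "the series" means these few. Any claim that something is new, unique, unknown or untested is made for them only; others in the source may bear on it.

Of the compounds shown here, three have so far been measured in a functional assay on the whole organism (stomach) with Rattus norvegicus as the target; on this read-out lower numbers stand for an effect already at smaller amounts and higher numbers for an effect only at larger amounts of compound. Compound 2 `N=C(S)CCCCCn1nc(-c2ccccc2)ccc1=O` gives 23.3 mg/kg, the lowest of the three numbers. Compound 1 `N=C(S)CCCn1nc(-c2ccccc2)ccc1=O` gives 31.9 mg/kg, and the step of a 1.4-fold lower number from compound 1 to compound 2 (0.14 log units; within the scatter) shows that a longer chain made no difference beyond the scatter. Compound 3 `CN(C)C(=S)CCCCCn1nc(-c2ccccc2)ccc1=O` gives 100 mg/kg; the steps of a 3.1-fold higher number from compound 1 to compound 3 (0.50 log units; beyond the scatter) and a 4.3-fold higher number from compound 2 to compound 3 (0.63 log units; beyond the scatter) lie beyond the scatter, but both concern the thioamide end of the chain rather than its length.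

Compound 4 `CC(Cn1nc(-c2ccccc2)ccc1=O)C(=N)S` has not yet been measured. It differs from compound 2 in that (a group of 5 heavy atoms (3 carbon, 1 nitrogen, 1 sulfur; no ring) in place of a group of 7 heavy atoms (5 carbon, 1 nitrogen, 1 sulfur; no ring), on a saturated chain carbon bound to an aromatic nitrogen), so the chain becomes shorter and branched while the thioamide end is kept. Among the compounds with values here, the only measured step that bears on a change of chain is a 1.4-fold lower number from compound 1 to compound 2 (0.14 log units; within the scatter), and it stayed within the scatter. Within the data shown here, no measured compound carries a branched chain, so that part of the change is untested. On this basis the expected step of a 1.5-fold higher number from compound 2 to compound 4 (0.18 log units; within the scatter) is small, and any shift is more likely toward a somewhat higher number than a lower one. Compound 4 is therefore estimated to give about 35 mg/kg, with a range from 18 mg/kg to 70 mg/kg.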

Compound 4, dose for half-maximal effect: 28.1 mg/kg
For compound 4 the middle estimate is 1.2-fold (0.10 log units) above the measured one, and the stated range covers the measured number.
By their numbers in this assay, from the lowest: compounds 2, 4 and 1 (each within the scatter of the next); then compound 3.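

In this assay, the first branched chain in the series adds something new: replacing the group of 7 heavy atoms with the branched group of 5 heavy atoms, on the saturated chain carbon bound to an aromatic nitrogen, gives a 1.2-fold higher number from compound 2 to compound 4 (0.08 log units; within the scatter), so neither shortening nor branching together moves the dose beyond normal experimental variation. Compound 1 and compound 4 carry groups with the same count of 5 heavy atoms, one straight and one branched, and a 1.1-fold lower number from compound 1 to compound 4 (0.06 log units; within the scatter) shows that this rearrangement also leaves the read-out within the scatter, so this position tolerates both changes of chain shape tested here. No separate measurement is available to explain this tolerance in the whole animal.

As far as these compounds go, it remains open whether the same tolerance would hold for a much longer chain, a chain containing a ring, or a chain with two methyl branches. It is also unknown how an amine or a carboxylic acid would behave in place of the thioamide end on the branched chain.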